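The source may report more compounds than this note shows. Statements on the series, on what has been measured and on what is new or still open speak of the compounds shown alone.

In a functional assay on OS-RC-2 cells (Homo sapiens) for cytotoxicity, read by MTT assay, with a stated time of 72 h (on this read-out higher numbers stand for weaker inhibition and lower numbers for stronger inhibition), compound 1 `O=C(Nc1ccc(-n2ncc3c(F)cccc32)cc1)Nc1ccc(Cl)c(C(F)(F)F)c1` gives 32000 nM, the highest of the three numbers available. Compound 2 `CNc1cccc2c1cnn2-c1ccc(NC(=O)Nc2ccc(Cl)c(C(F)(F)F)c2)cc1` gives 10600 nM, and compound 3 `COc1cccc2c1cnn2-c1ccc(NC(=O)Nc2ccc(Cl)c(C(F)(F)F)c2)cc1` gives 28800 nM. Both measured steps from compound 1 keep the 4-fluoro-1H-indazol-1-yl group and exchange only its fluoro: a 3.0-fold lower number from compound 1 to compound 2 (0.48 log units; beyond the scatter), whereas a 1.1-fold lower number from compound 1 to compound 3 (0.05 log units; within the scatter). Between those two, a 2.7-fold higher number from compound 2 to compound 3 (0.43 log units; beyond the scatter).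

Compound 4 `O=C(Nc1ccc(-n2ncc3ccncc32)cc1)Nc1ccc(Cl)c(C(F)(F)F)c1` is a different kind of change. Relative to compound 1 the difference is a group of 9 heavy atoms (6 carbon, 3 nitrogen; one five-membered aromatic ring with 2 hetero atoms, one six-membered aromatic ring with 1 hetero atom) in place of a group of 10 heavy atoms (7 carbon, 2 nitrogen, 1 fluorine; one five-membered aromatic ring with 2 hetero atoms, one six-membered aromatic ring of carbon only), on an aromatic carbon. The site is on an aromatic carbon of a six-membered aromatic ring of carbon only, para to a large group. None of the three measured steps replaces the whole 4-fluoro-1H-indazol-1-yl group, so none bears directly on this exchange; the closest information is that a single change on that group gave a modest lowering in one case and nothing beyond the scatter in the other. Going by the values given here, with no direct precedent, the step of a 1.3-fold lower number from compound 1 to compound 4 (0.11 log units; within the scatter) is expected to be none beyond the scatter, though with wide uncertainty in either direction. Compound 4 is therefore estimated at 25000 nM, expected to fall between 8000 nM and 70000 nM.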

Compound 4, half-maximal inhibitory concentration: > 32000 nM
Compound 4: only a limit was reported; the forecaster's own chance of this, stated with the estimate: 15%; middle value at least 1.2-fold (0.10 log units) from the limit.
By their numbers in this assay, from the lowest: compound 2; then compounds 3 and 1 (each within the scatter of the next).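

The step from the 4-fluoro-1H-indazol-1-yl group to the group with a nitrogen in its six-membered ring shows that this exchange gives no gain in this assay: a number no lower from compound 1 to compound 4 (the limit leaves the size open). Compound 4 is reported only as a limit, > 32000 nM, so the size of this step cannot be read, and whether compound 4 differs from compound 1 at all stays undecided: the limit of > 32000 nM in this assay, at which 1 of the 4 values shown sits. Among the changes shown at this group, a lower number beyond the scatter therefore still rests on the methylamino of compound 2 alone, and replacing the whole group with this nitrogen-containing one does not add a second case.

The compounds shown leave open how far compound 4 lies from compound 1, since only a value inside the range of the assay would settle that. They also leave open whether an amino or a dimethylamino group in place of the fluoro would follow methylamino or methoxy, and whether methylamino would keep its effect on the group that enters in compound 4.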